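Adding a Third Methoxy Group: Compound 2 to Compound 3

A few compounds are considered here, and "the series" means these few. Any claim that something is new, unique, unknown or untested is made for them only; others in the source may bear on it.

Measured so far:
- Compound 1, `COc1cc(-c2cc(/C=C/C(=O)c3ccc(N)cc3)[nH]n2)cc(OC)c1OC`: 9810 nM
- Compound 2, `COc1ccc(C(=O)/C=C/c2cc(-c3cc(OC)c(OC)c(OC)c3)n[nH]2)cc1OC`: 825 nM

Both compounds were tested in a functional assay on NCI-H522 cells (Homo sapiens) for inhibition, read by sulforhodamine B assay, with a stated time of 48 h; on this read-out higher numbers stand for lower toxicity in this test and lower numbers for higher toxicity in this test. Compound 2 has the lowest of the two numbers; its nearest neighbour is compound 1, whose value stands higher by a 12-fold lower number from compound 1 to compound 2 (1.08 log units; beyond the scatter). Among the measured compounds shown here, that single step, which exchanged the group attached to the carbonyl carbon, is the only measured change available.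

Compound 3, `COc1cc(C(=O)/C=C/c2cc(-c3cc(OC)c(OC)c(OC)c3)n[nH]2)cc(OC)c1OC`, keeps the whole skeleton of compound 2 and differs by methoxy in place of hydrogen on an aromatic carbon. For the measured compounds named here, no measured step touches this kind of small addition; the step from compound 1 to compound 2 concerns a different exchange of groups and offers no direct guidance on a single extra methoxy group. With nothing pointing either way, the expectation for compound 3 is a value close to that of compound 2, with a change of a 1.2-fold lower number from compound 2 to compound 3 (0.07 log units; within the scatter) that is not expected to exceed the scatter. The estimate for compound 3 is therefore 700 nM, within a range from 250 nM to 2500 nM.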

Compound 3, concentration lethal to 50% of the cells: 4220 nM
Estimate against measurement, compound 3: 6.0-fold (0.78 log units) below; measured number above the stated range.
By their numbers in this assay, from the lowest: compound 2; then compound 3; then compound 1.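

In this assay, a very small addition proves enough to matter: methoxy in place of hydrogen, on an aromatic carbon ortho to a methoxy group and meta to a large group, gives a 5.1-fold higher number from compound 2 to compound 3 (0.71 log units; beyond the scatter). Among the compounds shown here, the only earlier step, a 12-fold lower number from compound 1 to compound 2 (1.08 log units; beyond the scatter), exchanged a whole group on the carbonyl carbon, so it could not show that this ring also responds to a change of just 2 heavy atoms, or that an extra methoxy group here moves the number upward, towards lower toxicity in this test, so more methoxy groups on this ring do not simply go with a lower number. Nothing available explains why this single group has such an effect.

The compounds shown leave open whether this rise belongs to methoxy itself or would follow any group on this carbon, which a hydroxy group, a chlorine atom or an ethoxy group in the same place could help to separate. Also open, going by these compounds, is whether the step depends on the methoxy groups already on this ring, which the same addition on a ring without them could test.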